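The compounds below may be only part of what the source reports. "The series", "measured", "known", "first", "only" and "open" are said of these compounds alone.

Three compounds have been measured in a functional assay on HeLa cells (Homo sapiens) for cytotoxicity, read by cell counting, with a stated time of 48 h; a higher number here means that more compound is needed for the effect, a lower number that less compound is needed:

Compound 1, `CCCCCCCCCC(=O)O[C@H]1[C@H](O)[C@H](n2ccc(N)nc2=O)O[C@@H]1CO`, gives 0.09 ug/mL.
Compound 2, `C=CCCCCCCCCC(=O)O[C@H]1[C@H](O)[C@H](n2ccc(N)nc2=O)O[C@@H]1CO`, gives 0.05 ug/mL.
Compound 3, `CCCCCCCC/C=C\CCCCCCCC(=O)O[C@H]1[C@H](O)[C@H](n2ccc(N)nc2=O)O[C@@H]1CO`, gives 0.06 ug/mL.

All three share the same core and differ only in the acyl chain attached to it. Compound 3 stands second highest of the three numbers, but its separation from the others is small: the step of a 1.5-fold lower number from compound 1 to compound 3 (0.18 log units; within the scatter) and the step of a 1.2-fold higher number from compound 2 to compound 3 (0.08 log units; within the scatter) both fall within the scatter, as does a 1.8-fold lower number from compound 1 to compound 2 (0.26 log units; within the scatter). Taken together, changing the chain by adding a double bond or lengthening it has so far produced no shift that can be told apart from repeat measurement noise.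

Compound 4, `CCCCCCCCCCCCCCCCCCCC(=O)O[C@H]1[C@H](O)[C@H](n2ccc(N)nc2=O)O[C@@H]1CO`, is the next compound to be measured. It differs from compound 3 as follows: dodecyl in place of dec-1-en-1-yl on a saturated chain carbon, seven bonds along the chain from a carbonyl carbon. The change keeps the chain long and removes its double bond. The three measured steps all bear on it, since each also alters only the chain, and all three lie within the scatter. No step beyond the scatter is therefore expected in this assay, with the estimated step being a 1.2-fold higher number from compound 3 to compound 4 (0.07 log units; within the scatter). Compound 4 is expected to give about 0.07 ug/mL, with a plausible range from 0.03 ug/mL to 0.16 ug/mL.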

Compound 4, concentration for half-maximal effect: 0.1 ug/mL
Estimate against measurement, compound 4: 1.4-fold (0.15 log units) below, within the range that was stated.
By their numbers in this assay, from the lowest: compounds 2, 3, 1 and 4 (each within the scatter of the next).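

In this assay, swapping dec-1-en-1-yl for dodecyl gives a 1.7-fold higher number from compound 3 to compound 4 (0.22 log units; within the scatter), so removing the double bond from a long chain produces no shift that can be told apart from repeat measurement noise. The two other new comparisons agree: undecyl in place of vinyl gives a 2.0-fold higher number from compound 2 to compound 4 (0.30 log units; within the scatter), and decyl in place of hydrogen, which adds a long saturated stretch to the chain of compound 1, gives a 1.1-fold higher number from compound 1 to compound 4 (0.05 log units; within the scatter). No outside information bears on this result.

From the compounds shown here alone, all four compounds carry plain hydrocarbon chains, so it remains open how a much shorter acetyl group would behave at this place on the shared core. Going by these compounds, it is equally open whether a chain ending in an amine or a carboxylic acid would move the number beyond the scatter.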